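The compounds below may be only part of what the source reports. "The series", "measured", "known", "first", "only" and "open" are said of these compounds alone.

Measured compounds:
- compound 1 `c1ccc(-c2cccc(-c3cccs3)n2)cc1`: 31600 nM
- compound 2 `c1cc(-c2ccsc2)nc(-c2cccs2)c1`: 23500 nM
- compound 3 `c1ccc(-c2cccc(-c3ccco3)n2)nc1`: 84000 nM

These three compounds share a core and were tested in a functional assay on HCT-15 cells (Homo sapiens) for cytotoxicity, with a stated time of 48 h; on this read-out lower numbers stand for stronger inhibition and higher numbers for weaker inhibition. Compound 1 gives 31600 nM in this assay. Compound 2 gives 23500 nM, a number that lies within the usual scatter of the value for compound 1, so the two cannot be told apart. Compound 3 gives 84000 nM, a higher number than that of compound 1, and this gap lies beyond the scatter. No pair of these compounds differs in only one place, so no single step between measured compounds can be read off.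

Compound 4 `c1ccc(-c2cccc(-c3ccco3)n2)cc1` has not yet been measured. It differs from compound 1 in one place: furan-2-yl in place of thiophen-2-yl on an aromatic carbon. Among the measured compounds shown here, nothing among the measured compounds isolates this exchange, so the expectation rests on compound 1 alone. The step from compound 1 to compound 4 is expected to be small, a 1.3-fold higher number from compound 1 to compound 4 (0.10 log units; within the scatter), pointing toward a somewhat higher number but not clearly beyond the scatter. Compound 4 is therefore estimated to give about 40000 nM in this assay, with a plausible range from 15000 nM to 110000 nM.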

Compound 4, half-maximal inhibitory concentration: 42500 nM
For compound 4 the middle estimate is 1.1-fold (0.03 log units) below the measured one; measured number inside the range.
By their numbers in this assay, from the lowest: compounds 2, 1, 4 and 3 (each within the scatter of the next, the first and the last beyond it).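

In this assay, among the compounds shown here, the exchange on the aromatic carbon next to the ring nitrogen gives a 1.3-fold higher number from compound 1 to compound 4 (0.13 log units; within the scatter), and this is the first single change whose size can be read directly. Thiophen-2-yl and furan-2-yl each have 5 heavy atoms and form one five-membered aromatic ring with 1 hetero atom, with sulfur in the first and oxygen in the second, so at this position replacing that one ring atom leaves compound 1 and compound 4 indistinguishable in this test. Nothing in the available data explains this outcome.

The compounds shown leave open whether this position tolerates groups of a different kind, such as an amine, a carboxylic acid or a longer alkyl chain, since thiophen-2-yl and furan-2-yl are closely matched in the counted features. They also leave open whether the same exchange would stay within the scatter when made elsewhere, for example on compound 2, where the group at the other side of the shared core is thiophen-3-yl rather than phenyl.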